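Fluoro in Place of Nitro: Expected Effect on Cytotoxicity

The source may hold more compounds than are shown below. What is called first, only, known or untested is meant among the compounds shown, and "the series" means these compounds.

Compound 1 `COc1ccccc1-c1nnc(-c2ccc(C(=O)N/N=C/c3ccc([N+](=O)[O-])cc3)cc2)o1` was tested in an ADME assay on THP-1 cells (Homo sapiens) for cytotoxicity (a higher number here means a weaker inhibitor, a lower number a stronger inhibitor), where compound 1 gives 203000 nM. Compound 2 `COc1ccccc1-c1nnc(-c2ccc(C(=O)N/N=C/c3cccc(F)c3)cc2)o1` differs from it only by 3-fluorophenyl in place of 4-nitrophenyl on a carbon with a double bond to nitrogen, and in this assay compound 2 gives 353000 nM. Only these two numbers are measured, and they lie within the scatter of each other: a 1.7-fold higher number from compound 1 to compound 2 (0.24 log units; within the scatter). Compound 3 `COc1ccccc1-c1nnc(-c2ccc(C(=O)N/N=C/c3ccc(F)cc3)cc2)o1` carries fluoro in place of nitro on an aromatic carbon, which read one bond further out is 4-nitrophenyl to 4-fluorophenyl. Among the measured compounds shown here, the single step that bears on this change is the one just described, which also traded the nitrophenyl for a fluorophenyl and stayed within the scatter. A step of similar size, and nothing beyond the scatter, is therefore expected in this assay, namely a 1.2-fold higher number from compound 1 to compound 3 (0.09 log units; within the scatter). Compound 3 is estimated at 250000 nM, with a range from 100000 nM to 600000 nM.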

Compound 3, half-maximal inhibitory concentration: 427000 nM
For compound 3 the middle estimate is 1.7-fold (0.23 log units) below the measured one; the measured number falls inside the stated range.
By their numbers in this assay, from the lowest: compounds 1, 2 and 3 (each within the scatter of the next, the first and the last beyond it).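

Among the compounds shown here, exchanging the nitro directly for fluoro on the same aromatic carbon gives a 2.1-fold higher number from compound 1 to compound 3 (0.32 log units; beyond the scatter) in this assay and so provides the first step in this small set that lies beyond the scatter, though only modestly. Moving the fluorine, by contrast, from 3-fluorophenyl to 4-fluorophenyl gives a 1.2-fold higher number from compound 2 to compound 3 (0.08 log units; within the scatter) and so shows no readable effect of where fluoro sits in this pair. Nothing available here explains the step from nitro to fluoro.

On this ring, the comparison covers only nitro and fluoro. On these data alone, how an amine, a carboxylic acid or a nitrile on the same aromatic carbon would compare with compound 1 and compound 3 remains open, as does whether the modest step from nitro to fluoro would also appear on a different core.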